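Cytotoxicity limits in the series and the step to compound 4

The source may hold more compounds than are shown below. What is called first, only, known or untested is meant among the compounds shown, and "the series" means these compounds.

Compound 1 `Cc1ccc(NC(=O)C(=O)NC(c2nc(C)c(CCO)s2)C2CCCCN2)c(F)c1` in an ADME assay on TZM-b1 cells (Homo sapiens) for cytotoxicity, read by XTT assay, with a stated time of 3 days (a higher number here means that more compound is tolerated, a lower number that less compound is tolerated), gives > 78800 nM, which is a limit of the assay and not a number.
Compound 2 `CC(=O)c1ccc(NC(=O)C(=O)NC(c2nc(C)c(CCO)s2)C2CCCCN2)cc1` in this assay gives > 77300 nM, again a limit.
Compound 3 `Cc1ccc(NC(=O)C(=O)NC(c2nc(C)c(CO)s2)C2CCCCN2)cc1F` in this assay gives > 88000 nM, also a limit.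

Every value shown sits at a limit (the limit of > 77300 nM in this assay, at which 1 of the 3 values shown sits, (the limit of > 78800 nM in this assay, at which 1 of the 3 values shown sits), (the limit of > 88000 nM in this assay, at which 1 of the 3 values shown sits)), so compound 3 stands at the top of the measured range together with the other two, with no number that orders it against them. Among the compounds with values here, the single computed step, a step that the two limits leave unreadable from compound 1 to compound 2, cannot be read because the limit of > 77300 nM in this assay, at which 1 of the 3 values shown sits, and the limit of > 78800 nM in this assay, at which 1 of the 3 values shown sits, both cap the values. Compound 4 `Cc1nc(C(NC(=O)C(=O)Nc2ccc(F)c(Cl)c2)C2CCCCN2)sc1CO` differs from compound 3 by 3-chloro-4-fluorophenyl in place of 3-fluoro-4-methylphenyl on an amide-type nitrogen. Within the data shown here, no measured step bears on this replacement: the one computed step concerns a different change and is itself unreadable. With all three values at limits, no direction or size of step in this assay beyond the scatter can be drawn, and the expectation is that compound 4 likewise runs to the limit. Compound 4 is therefore estimated at 85000 nM in this assay, with a range from 30000 nM to 250000 nM. The implied step, an at least 1.0-fold lower number from compound 3 to compound 4 (0.01 log units; that floor lies within the scatter), is expected to stay within the scatter.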

Compound 4, half-maximal cytotoxic concentration: > 77800 nM
Compound 4: a limit, no number (the forecaster's own chance of this, stated with the estimate: 85%); the middle value is on the limit's open side.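

No step can be read from compound 3 to compound 4, as both values are limits of the assay and not numbers. The compounds shown leave open the concentration at which any of them becomes cytotoxic in this assay, and whether 3-chloro-4-fluorophenyl in place of 3-fluoro-4-methylphenyl changes the read-out at all.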